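The source may report more compounds than this note shows. Statements on the series, on what has been measured and on what is new or still open speak of the compounds shown alone.

Three amides built on one shared core have been measured in a functional assay on HepG2 cells (Homo sapiens) for antiproliferative activity, read by CCK-8 assay, with a stated time of 72 h; on this read-out higher numbers stand for weaker inhibition and lower numbers for stronger inhibition. Compound 1 `COc1cccc(C(=O)Nc2cccc(-c3oc4cc(-c5ccc(F)cc5)ccc4c(=O)c3O)c2)c1` gives 9950 nM, compound 2 `O=C(Nc1cccc(-c2oc3cc(-c4ccc(F)cc4)ccc3c(=O)c2O)c1)c1cccc(F)c1` gives 15500 nM, and compound 3 `Cc1cc(C(=O)Nc2cccc(-c3oc4cc(-c5ccc(F)cc5)ccc4c(=O)c3O)c2)ccc1F` gives 9540 nM. Compound 2 stands highest of the three numbers, yet its steps to the others, a 1.6-fold higher number from compound 1 to compound 2 (0.19 log units; within the scatter) and a 1.6-fold lower number from compound 2 to compound 3 (0.21 log units; within the scatter), both lie within the scatter, as does a 1.0-fold lower number from compound 1 to compound 3 (0.02 log units; within the scatter). Compound 4 `O=C(Nc1cccc(-c2oc3cc(-c4ccc(F)cc4)ccc3c(=O)c2O)c1)c1cnc(Cl)nc1Cl` has not yet been measured. It differs from compound 2 in one place: 2,4-dichloropyrimidin-5-yl in place of 3-fluorophenyl on a carbonyl carbon. The ring that leaves is one six-membered aromatic ring of carbon only; the ring that enters is one six-membered aromatic ring with 2 hetero atoms and carries 2 hydrogen-bond acceptors where the old ring had none. Among the compounds with values here, no measured step swaps this ring for one with hetero atoms; the changes seen so far, fluoro in place of methoxy and 4-fluoro-3-methylphenyl in place of 3-fluorophenyl, all stayed within the scatter. Lacking a closer precedent, the estimate for compound 4 in this assay is 12000 nM, between 4000 nM and 40000 nM, an expected step of a 1.3-fold lower number from compound 2 to compound 4 (0.11 log units; within the scatter) that is not foreseen to reach beyond the scatter.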

Compound 4, half-maximal inhibitory concentration: > 100000 nM
Compound 4: a limit, no number; the forecaster's own chance of this, stated with the estimate: 10%; middle value at least 8.3-fold (0.92 log units) away from the limit.
By their numbers in this assay, from the lowest: compounds 3, 1 and 2 (each within the scatter of the next). At a limit, above all of these: compound 4.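

In this assay compound 4 stands at a limit and gives no number: the limit of > 100000 nM in this assay, at which 1 of the 4 values shown sits. Within the data shown here, the substituent on this carbonyl carbon had so far made no difference beyond the scatter among 3-methoxyphenyl, 3-fluorophenyl and 4-fluoro-3-methylphenyl, but 2,4-dichloropyrimidin-5-yl gives an at least 6.4-fold higher number from compound 2 to compound 4 (0.80 log units; beyond the scatter), an at least 10-fold higher number from compound 3 to compound 4 (1.02 log units; beyond the scatter) and an at least 10-fold higher number from compound 1 to compound 4 (1.00 log units; beyond the scatter). The position is therefore not indifferent to every ring, and this swap of a carbon-only ring for one with hetero atoms is the first change shown to reach beyond the scatter, with all three steps resting on the limit.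

The ring nitrogens and the two chlorine atoms enter together in one step, so the compounds shown do not tell which of them goes with the loss of activity. A 2,4-dichlorophenyl or an unsubstituted pyrimidin-5-yl on the same carbonyl carbon would separate the two.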